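Inverting One Cyclopropane Stereocentre: Compound 1 to Compound 4

The source may report more compounds than this note shows. Statements on the series, on what has been measured and on what is new or still open speak of the compounds shown alone.

Measured compounds:
compound 1, `CCOC(=O)[C@@]1(C(=O)Nc2ccccc2Cl)C[C@H]1c1cc(OC)c(OC)c(OC)c1` — 34300 nM
compound 2, `COc1cc([C@@H]2C[C@@]2(CO)C(=O)Nc2ccccc2Cl)cc(OC)c1OC` — 24500 nM
compound 3, `CCOC(=O)[C@@]1(C(=O)Nc2ccccc2)C[C@H]1c1cc(OC)c(OC)c(OC)c1` — 48700 nM

In a functional assay on QGY cells (Homo sapiens) for cytotoxicity, read by MTT assay, with a stated time of 48 h (a higher number here means a weaker inhibitor, a lower number a stronger inhibitor), compound 1 gives 34300 nM, the second highest of the three numbers. Compound 2 gives 24500 nM and compound 3 gives 48700 nM; both sit within the scatter of compound 1, as the steps show: a 1.4-fold lower number from compound 1 to compound 2 (0.15 log units; within the scatter) and a 1.4-fold higher number from compound 1 to compound 3 (0.15 log units; within the scatter). Compound 4, `CCOC(=O)[C@@]1(C(=O)Nc2ccccc2Cl)C[C@@H]1c1cc(OC)c(OC)c(OC)c1`, differs from compound 1 as follows: the two compounds have the same atoms and bonds and differ only in configuration as drawn: 1 of 2 stereo elements differ; a stereocentre at a saturated ring carbon is drawn S in compound 1 and R in compound 4. Within the data shown here, neither measured step touches a configuration; each swaps a substituent and stays within the scatter, so no measured step bears on this change, and the expectation is anchored to compound 1 with a wide range. In this assay compound 4 is expected to give 34300 nM, between 10000 nM and 120000 nM. The estimated step is no change at the digits printed from compound 1 to compound 4 (within the scatter), with no direction favoured.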

Compound 4, half-maximal inhibitory concentration: > 100000 nM
Compound 4 gave a limit, no number (the forecaster's own chance of this, stated with the estimate: 10%); at least 2.9-fold (0.46 log units) between middle value and limit.
By their numbers in this assay, from the lowest: compounds 2, 1 and 3 (each within the scatter of the next). At a limit, above all of these: compound 4.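

Unlike the substituent swaps among the earlier compounds, inverting this stereocentre at a saturated ring carbon moves the result in this assay beyond the scatter, with an at least 2.9-fold higher number from compound 1 to compound 4 (0.46 log units; beyond the scatter). Compound 4 gives > 100000 nM, which is a limit and not a number. The configuration at this carbon therefore matters in this assay, since nothing else separates the pair: the fact that compounds 1 and 4 differ only in the configuration as drawn

The compounds shown leave open how the other stereocentre bears on the result. They also leave open whether a carboxylic acid or an amine in place of ethoxycarbonyl would behave differently under the same inversion.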